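This account rests on a few compounds, and the source may have more. Where it says the series, first, only, none or still open, it means among the compounds named here.

Of the compounds shown here, three built on a shared core have numbers so far in a functional assay on HCT-116 cells (Homo sapiens) for antiproliferative activity, read by sulforhodamine B assay, with a stated time of 72 h (on this read-out lower numbers stand for stronger inhibition and higher numbers for weaker inhibition), and all of them fall in a narrow band. Compound 1 `Cn1ncc(Cl)c1-c1cc(C(=O)N[C@@H]2CN[C@H](CC(O)CO)C[C@H]2c2ccc(F)c(F)c2)oc1Cl` gives 800 nM here, compound 2 `Cn1ncc(Cl)c1-c1cc(C(=O)N[C@@H]2CN[C@H](CCCO)C[C@H]2c2ccc(Cl)c(Cl)c2)oc1Cl` gives 510 nM here, and compound 3 `Cn1ncc(Cl)c1-c1cc(C(=O)N[C@@H]2CN[C@H](CCN3CCCCC3)C[C@H]2c2ccc(Cl)c(Cl)c2)oc1Cl` gives 1020 nM here. Compound 3 lies within the usual scatter of both others, so these numbers do not set it apart from them. Compound 4 `Cn1ncc(Cl)c1-c1cc(C(=O)N[C@@H]2CN[C@H](CC(=O)NCC(O)CO)C[C@H]2c2ccc(Cl)c(Cl)c2)oc1Cl` differs from compound 3 in one place: (2,3-dihydroxypropyl)carbamoyl in place of (piperidin-1-yl)methyl on a saturated chain carbon bound to a saturated ring carbon and this change sits on a saturated chain carbon bound to a saturated ring carbon. Among the measured compounds shown here, the one measured step on this chain is a 2.0-fold higher number from compound 2 to compound 3 (0.30 log units; within the scatter) and it stays within the scatter. Compound 1 also carries a 2,3-dihydroxypropyl group and gives 800 nM here, but it differs elsewhere too, so it is only a loose guide. For the measured compounds named here, no measured compound holds the carbamoyl group, so the range stays wide. In this assay the expected step is a 1.1-fold lower number from compound 3 to compound 4 (0.05 log units; within the scatter) and this would lie within the scatter. Compound 4 is estimated at 900 nM with an expected range from 350 nM to 2500 nM in repeated measurements.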

Compound 4, half-maximal inhibitory concentration: 7090 nM
The estimate for compound 4 lay 7.9-fold (0.90 log units) below the measured number, outside the stated range (above it).
By their numbers in this assay, from the lowest: compounds 2, 1 and 3 (each within the scatter of the next); then compound 4.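

In this assay, among the compounds shown here, the group on this saturated chain carbon bound to a saturated ring carbon clearly matters: a 7.0-fold higher number from compound 3 to compound 4 (0.84 log units; beyond the scatter) and a 14-fold higher number from compound 2 to compound 4 (1.14 log units; beyond the scatter) both lie beyond the scatter, whereas the one earlier step, a 2.0-fold higher number from compound 2 to compound 3 (0.30 log units; within the scatter), stayed within it. For the compounds shown here, the (2,3-dihydroxypropyl)carbamoyl group is thus the first group here to give a number set apart from the others, so this position does not accept every replacement equally. Nothing available explains why the number rises with this change. Because the change swaps a ring-bearing amine chain for an amide with a diol end, the compounds shown cannot separate the carbamoyl link from the dihydroxypropyl end. A plain methylcarbamoyl group or a carboxylic acid at this place could help tell the two apart.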